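Sulfonamide variation at the sulfonyl sulfur: compound 2 to compound 3

A few compounds are considered here, and "the series" means these few. Any claim that something is new, unique, unknown or untested is made for them only; others in the source may bear on it.

Measured so far:
compound 1 `CCCCCCS(=O)(=O)N[C@H]1C2CC[C@H](C2)[C@@H]1C/C=C\CCCC(=O)O` — 13300 nM
compound 2 `O=C(O)CCC/C=C\C[C@H]1[C@@H]2CCC(C2)[C@@H]1NS(=O)(=O)CCc1ccccc1` — 8200 nM

In a functional assay (plasma) for inhibition, with Oryctolagus cuniculus as the target (on this read-out lower numbers stand for stronger inhibition and higher numbers for weaker inhibition), compound 1 gives 13300 nM and compound 2 gives 8200 nM. Within the data shown here, compound 2 holds the lowest of the two numbers, with compound 1 as its only neighbour; the gap between them is within the scatter, so no order can be read from it. Among the measured compounds shown here, the single measured step is a 1.6-fold lower number from compound 1 to compound 2 (0.21 log units; within the scatter), brought about by phenyl in place of butyl on a saturated chain carbon, two bonds along the chain from a sulfonyl sulfur.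

Compound 3 `O=C(O)CCC/C=C\C[C@H]1[C@@H]2CCC(C2)[C@@H]1NS(=O)(=O)c1ccc(O)cc1` is not yet measured. It differs from compound 2 by 4-hydroxyphenyl in place of phenethyl on a sulfonyl sulfur. The measured step touches the same region, the group carried by the sulfonyl sulfur, but it exchanged one chain end for another and stayed within the scatter. For the measured compounds named here, no measured compound carries an aromatic ring directly on the sulfonyl sulfur, and none carries a hydroxyl, so the step from compound 2 to compound 3 has no close precedent. The expected step of a 1.3-fold lower number from compound 2 to compound 3 (0.10 log units; within the scatter) is therefore set near no change, with a wide range. Compound 3 is estimated to give 6500 nM in this assay, between 1500 nM and 28000 nM.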

Compound 3, half-maximal inhibitory concentration: 500 nM
Compound 3: the middle estimate sits 13-fold (1.11 log units) above what was measured, and the stated range ends above it.
By their numbers in this assay, from the lowest: compound 3; then compounds 2 and 1 (each within the scatter of the next).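

In this assay, the group on the sulfonyl sulfur proves able to shift the read-out strongly: the earlier exchange of one chain end for another stayed within the scatter, whereas 4-hydroxyphenyl in place of phenethyl gives a 16-fold lower number from compound 2 to compound 3 (1.21 log units; beyond the scatter), and 4-hydroxyphenyl in place of hexyl gives a 27-fold lower number from compound 1 to compound 3 (1.42 log units; beyond the scatter). Compound 3 therefore stands apart from both compounds with a chain on the sulfonyl sulfur, but the change from compound 2 both removes the saturated chain carbons that hold the aromatic ring and adds a hydroxyl, so the size of the step cannot be divided between these two differences. Nothing measured here bears on the reason for this step.

The compounds shown leave open whether the gain follows from the aromatic ring sitting on the sulfonyl sulfur or from the hydroxyl, a distinction that a plain phenyl on that sulfur would address. They also leave open whether the hydroxyl can be replaced, as a 4-methoxyphenyl or a 4-aminophenyl at the same place would show.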